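Swapping the triazole substituent in a weak antiproliferative series

The compounds below may be only part of what the source reports. "The series", "measured", "known", "first", "only" and "open" are said of these compounds alone.

Measured compounds:
compound 1, `CN(CCNCc1cn(-c2ccccc2Cl)nn1)CCNc1ccnc2cc(Cl)ccc12` — 12000 nM
compound 2, `CN(CCNCc1cn(Cc2nc3cc(Cl)ccc3[nH]2)nn1)CCNc1ccnc2cc(Cl)ccc12` — 65000 nM

In a functional assay on HCC827 cells (Homo sapiens) for antiproliferative activity, read by sulforhodamine B assay, with a stated time of 72 h (a higher number here means a weaker inhibitor, a lower number a stronger inhibitor), compound 1 gives 12000 nM, and in this assay compound 2 gives 65000 nM, the higher of the two numbers. Going by the values given here, the only measured step, a 5.4-fold higher number from compound 1 to compound 2 (0.73 log units; beyond the scatter), changes the group on the aromatic nitrogen of the shared core. Compound 3, `CN(CCNCc1cn(CCCn2nn[nH]c2=O)nn1)CCNc1ccnc2cc(Cl)ccc12`, alters the same position again: a group of 8 heavy atoms (3 carbon, 4 nitrogen, 1 oxygen; one five-membered aromatic ring with 4 hetero atoms) in place of a group of 10 heavy atoms (7 carbon, 2 nitrogen, 1 chlorine; one five-membered aromatic ring with 2 hetero atoms, one six-membered aromatic ring of carbon only), on a saturated chain carbon bound to an aromatic nitrogen. Among the compounds with values here, no measured step covers this exact exchange, so the one known step serves only as a guide to how much a change at this position can move the number, and it points to a modest shift. With no direction given by the data, compound 3 is expected to stay near compound 2, with a step of a 1.3-fold lower number from compound 2 to compound 3 (0.11 log units; within the scatter) in this assay. The estimate for compound 3 is 50000 nM, expected to fall between 15000 nM and 150000 nM.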

Compound 3, half-maximal inhibitory concentration: > 200000 nM
Compound 3 gave a limit, no number (the forecaster's own chance of this, stated with the estimate: 15%); middle value at least 4.0-fold (0.60 log units) away from the limit.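

In this assay compound 3 gives a limit of the assay, not a number: the limit of > 200000 nM in this assay, at which 1 of the 3 values shown sits. Even so, replacing 5-chloro-1H-benzimidazol-2-yl with the group holding a five-membered aromatic ring with 4 hetero atoms gives an at least 3.0-fold higher number from compound 2 to compound 3 (0.48 log units; beyond the scatter), so the number moves further in the same direction as the earlier step rather than back. Measured against 2-chlorophenyl on the aromatic nitrogen, the whole change gives an at least 16-fold higher number from compound 1 to compound 3 (1.22 log units; beyond the scatter), which shows that this position can shift the number by a large step, not only a modest one.

On these data alone, how far compound 3 lies past its limit remains unknown, so the true size of both steps does too. As far as these compounds go, whether an amine, a carboxylic acid or a longer chain carrying 2-chlorophenyl at this position would bring the number down remains open.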